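The source may hold more compounds than are shown below. What is called first, only, known or untested is meant among the compounds shown, and "the series" means these compounds.

Measured in a functional assay on MOLT-4 cells (Homo sapiens) for antiproliferative activity, with a stated time of 48 h; a lower number here means a stronger inhibitor, a higher number a weaker inhibitor:
compound 1 `C=C(Br)C(=O)Nc1ccc(/C=C/C(=O)c2ccc(F)cc2)cc1`: 660 nM
compound 2 `C=C(Br)C(=O)Nc1ccc(/C=C/C(=O)c2ccc(Cl)cc2)cc1`: 810 nM
compound 3 `C=C(Br)C(=O)Nc1ccc(/C=C/C(=O)c2ccc(C)cc2)cc1`: 1700 nM

Of these three, compound 3 has the highest number, 1700 nM, which makes it the weakest inhibitor of the set. Fluoro and chloro are not separated, with a 1.2-fold higher number from compound 1 to compound 2 (0.09 log units; within the scatter). Methyl stands modestly apart from both, with a 2.6-fold higher number from compound 1 to compound 3 (0.41 log units; beyond the scatter) and with a 2.1-fold higher number from compound 2 to compound 3 (0.32 log units; beyond the scatter).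

The next compound, compound 4 `C=C(Br)C(=O)Nc1ccc(/C=C/C(=O)c2cccs2)cc1`, differs by more than a single group on the ring: thiophen-2-yl in place of 4-methylphenyl on a carbonyl carbon. Thiophen-2-yl replaces 4-methylphenyl on a carbonyl carbon, and the rest of the core stays as it is. For the measured compounds named here, no measured step exchanges the ring itself, so the three steps above bear on this change only indirectly. They show that exchanges on that ring have so far moved the number only modestly, the largest being a 2.6-fold higher number from compound 1 to compound 3 (0.41 log units; beyond the scatter). Compound 4 also lacks the methyl group of compound 3, which sits at 1700 nM, the top of the measured range. A small move toward a lower number in this assay is therefore expected, and it may not clear the scatter. The expected step is a 1.7-fold lower number from compound 3 to compound 4 (0.23 log units; within the scatter). For compound 4 the estimated value is 1000 nM, with an expected range of 400 nM to 2500 nM.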

Compound 4, half-maximal inhibitory concentration: 550 nM
For compound 4 the middle estimate is 1.8-fold (0.26 log units) above the measured one; measured number inside the range.
By their numbers in this assay, from the lowest: compounds 4, 1 and 2 (each within the scatter of the next); then compound 3.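

For the compounds shown here, the exchange at the carbonyl carbon replaces the whole ring rather than a group on it, and in this assay thiophen-2-yl in place of 4-methylphenyl gives the largest step so far, though still a modest one (a 3.1-fold lower number from compound 3 to compound 4 (0.49 log units; beyond the scatter)). Set against the two halogen-bearing rings, the same ring is not separated from either (a 1.5-fold lower number from compound 2 to compound 4 (0.17 log units; within the scatter) and a 1.2-fold lower number from compound 1 to compound 4 (0.08 log units; within the scatter)), so a five-membered aromatic ring with one sulfur atom sits level with 4-chlorophenyl and 4-fluorophenyl, and compound 3 alone stands apart as the weakest of the four. Nothing available for this series accounts for that result, and the numbers alone cannot say what sets 4-methylphenyl apart.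

Going by these compounds, what stays open is whether a furan-2-yl or pyridinyl ring at this carbonyl carbon, or a phenyl ring bearing an amine or a carboxylic acid, would stay level with compound 1, compound 2 and compound 4 or fall with compound 3. On these data alone, it is also open whether a methyl group on the thiophen-2-yl ring would raise the number, as methyl does on the phenyl ring.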